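The source may report more compounds than this note shows. Statements on the series, on what has been measured and on what is new or still open speak of the compounds shown alone.

Measured so far:
compound 1, `Cc1ccnc(/C(N)=N/NC(=S)N2CCCC2)c1`: 58.5%
compound 2, `Cc1ccnc(/C(N)=N/NC(=S)N2CCCCCC2)c1`: 36.3%

Compound 1 has the highest of the two numbers in a functional assay on A-431 cells (Homo sapiens) for cytotoxicity, read by MTT assay, with a stated time of 72 h, tested at 1 uM; a higher number here means more inhibition of growth at the concentration tested, a lower number less inhibition of growth. Going by the values given here, compound 2 gives 36.3% in this assay, a number that falls well below compound 1, beyond the usual scatter of this kind of measurement; no step between the two has been worked out here, so only their values speak.

Compound 3, `Cc1ccnc(/C(N)=N/NC(=S)N2CCOCC2)c1`, has not yet been measured in this assay. It differs from compound 1 in one place: morpholin-4-yl in place of pyrrolidin-1-yl on a thiocarbonyl carbon. The ring that enters carries one hydrogen-bond acceptor where the ring that leaves carries none.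

Among the compounds with values here, with only two measured compounds and no computed step between them, there is little to lean on. Since the two measured rings already differ by a span beyond the scatter, a change of ring on the thiocarbonyl carbon is expected to shift the number, and the expectation is a moderate drop from compound 1 to compound 3, a number 12.5 percentage points lower from compound 1 to compound 3 (beyond the scatter), close to the edge of the scatter. Compound 3 is therefore estimated to give 46%, with a range from 22% to 68%.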

Compound 3, percent growth inhibition at one concentration: 33.6%
For compound 3 the middle estimate is 12.4 percentage points above the measured one, within the range that was stated.
By their numbers in this assay, from the lowest: compounds 3 and 2 (each within the scatter of the next); then compound 1.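

In this assay the swap of pyrrolidin-1-yl for morpholin-4-yl on the thiocarbonyl carbon gives a number 24.9 percentage points lower from compound 1 to compound 3 (beyond the scatter) and so shows, in a single clean step, that this position responds to a change of ring. Compound 3 at 33.6% and compound 2 at 36.3% lie within the scatter of each other, so two different replacements of the ring in compound 1 end up at a similar level. The entering ring is six-membered and also carries one hydrogen-bond acceptor, so these two features change together in this one step, and no measurement at hand gives a reason for the drop.

Still open, as far as these compounds go, is whether ring size or the ring oxygen accounts for the step: a piperidin-1-yl ring, six-membered without the oxygen, or a thiomorpholine ring, with sulfur where the oxygen stands, would help separate the two. Also open, from the compounds shown here alone, is whether a ring is needed on this carbon at all, which an open-chain dimethylamino group could address.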